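The source may report more compounds than this note shows. Statements on the series, on what has been measured and on what is new or still open speak of the compounds shown alone.

Measured compounds:
compound 1 `CC(C)(C)Cc1csc(N)c1C(=O)c1ccc(Cl)cc1` gives 5% in an assay on CHO cells for displacement of a labelled ligand from adenosine receptor A3 (Homo sapiens), read by scintillation counting, tested at 10 uM; on this read-out lower numbers stand for less inhibition and higher numbers for more inhibition at the one concentration tested (going by the name of the read-out)
compound 2 `CC(C)(C)Cc1csc(N)c1C(=O)c1cccc(Cl)c1` gives 8% in this assay
compound 3 `COc1cccc(-c2sc(N)c(C(=O)c3ccc(Cl)cc3)c2CC(C)(C)C)c1` gives 1% in this assay

Of the compounds shown here, three on a shared core have been measured in this assay, and all three sit close together at the low end of the scale. Compound 2 gives 8%; compound 1 gives 5% and compound 3 gives 1%, and both of these lie within the scatter of the number for compound 2, so no order among the three can be read from the data.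

Among the compounds with values here, only one single-point step has been measured: a number 4 percentage points lower from compound 1 to compound 3 (within the scatter), which brought 3-methoxyphenyl in place of hydrogen on an aromatic carbon and changed nothing beyond the scatter.

Compound 4 `CC(C)(C)Cc1csc(N)c1C(=O)c1ccc(Cl)c(Cl)c1` is not yet measured. It differs from compound 2 in one place: chloro in place of hydrogen on an aromatic carbon. Within the data shown here, no measured step touches this position, so the only guide is that every change seen so far, including the one from compound 1 to compound 3, left the number where it was. On that basis compound 4 is expected to stay in the same low region, with a number 1 percentage points higher from compound 2 to compound 4 (within the scatter) amounting to nothing beyond the scatter. The estimate for compound 4 is 9%, with a range from 0% to 22%.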

Compound 4, a percentage reported as inhibition, at one concentration (the size of the read-out at that concentration, not a potency): 10%
Estimate against measurement, compound 4: 1 percentage points below; the range from low to high includes it.
By their numbers in this assay, from the lowest: compounds 3, 1, 2 and 4 (each within the scatter of the next).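

At the aromatic carbon ortho to a chloro group and para to a large group, chloro in place of hydrogen gives a number 2 percentage points higher from compound 2 to compound 4 (within the scatter) in this assay, so this position, which the earlier step did not touch, now has a measured step and it stays within the scatter. Compound 4 can also be reached from the compound with its chloro elsewhere on the same ring, and that step, a number 5 percentage points higher from compound 1 to compound 4 (within the scatter), stays within the scatter too, so on this read-out a second chloro on this six-membered aromatic ring does not set compound 4 apart from either compound with one chloro. No evidence is at hand that bears on this result.

The compounds shown leave open whether a group other than chloro at this position, such as an amine or a carboxylic acid, would give a number beyond the scatter of these values. They also leave open whether any change to the shared core, such as a longer chain in place of the one it carries, would give a number clear of the low end of the scale.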